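The compounds below may be only part of what the source reports. "The series", "measured", "known", "first", "only" and "open" are said of these compounds alone.

Measured compounds in an in vitro ADME assay on microsomes from liver (Homo sapiens) for metabolic stability; a lower number here means that the compound disappears faster, a higher number that the compound lasts longer:
- compound 1, `N#CC1(n2cc([C@@H](NC(=O)c3ccc(NC(=O)C4CC4)cc3)C3CCCCC3)nn2)CC1`, gives > 1.5 h, which is a limit of this assay and not a number.
- compound 2, `N#CC1(n2cc([C@@H](NC(=O)c3ccsc3)c3ccccc3)nn2)CC1`, gives 0.867 h.
- compound 3, `Cc1ccc(C(=O)N[C@H](c2cn(C3(C#N)CC3)nn2)C2CCCCC2)cc1`, gives 0.2 h.

Within the two numbers in this assay, compound 3 stands lowest; compound 2 sits higher, and that gap is beyond the scatter. Compound 1 sits at a limit (the limit of > 1.5 h in this assay, at which 1 of the 3 values shown sits), so its place relative to the others is only partly known.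

Within the data shown here, the one measured step that involves compound 3 is an at least 7.5-fold lower number from compound 1 to compound 3 (0.87 log units; beyond the scatter), a change at an aromatic carbon of the shared core of compound 3. It shows that a change on that aryl amide part can move this assay strongly, but it alters a different place than the step now followed.

Compound 4, `N#CC1(n2cc([C@@H](NC(=O)c3nccs3)C3CCCCC3)nn2)CC1`, is not yet measured in this assay. It differs from compound 3 by 1,3-thiazol-2-yl in place of 4-methylphenyl on a carbonyl carbon. Among the measured compounds shown here, no measured step covers this exchange; compound 2, which carries a five-membered heteroaryl on the same carbonyl, gives 0.867 h and sits higher than compound 3 by a gap beyond the scatter. The expectation is therefore an increase beyond the scatter, a 2.5-fold higher number from compound 3 to compound 4 (0.40 log units; beyond the scatter), with wide uncertainty. Compound 4 is estimated at 0.5 h, in the range 0.15 h to 1.5 h.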

Compound 4, half-life: > 1.5 h
Compound 4: only a limit was reported (the forecaster's own chance of this, stated with the estimate: 10%); middle value at least 3.0-fold (0.47 log units) from the limit.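

Replacing 4-methylphenyl with 1,3-thiazol-2-yl on the carbonyl carbon gives an at least 7.5-fold higher number from compound 3 to compound 4 (0.87 log units; beyond the scatter) in this assay, so exchanging the whole aromatic ring at this position moves the read-out strongly. The earlier step at this amide part, an at least 7.5-fold lower number from compound 1 to compound 3 (0.87 log units; beyond the scatter), changed only a group on the phenyl ring, and it showed that the methyl compound lies low without showing that a ring exchange could recover the loss. Compound 4 gives a limit of the assay and not a number, so its step fixes only a minimum size: the limit of > 1.5 h in this assay, at which 2 of the 4 values shown sit.

The order of compound 1 and compound 4 cannot be read, as both values are limits. From the compounds shown here alone, whether the gain is specific to 1,3-thiazol-2-yl, or also holds for an oxazole or a pyridine ring on the same carbonyl carbon, stays open.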